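The source may report more compounds than this note shows. Statements on the series, on what has been measured and on what is new or still open speak of the compounds shown alone.

Compound 2, with the structure `CC(CC(=O)O)N1Cc2ccc(NC(=O)c3ccc(N4CCNCC4)cc3)cc2C1=O`, gives 3740 nM in a functional assay on a cell-free system (Platelet, plasma, Homo sapiens) for inhibition; on this read-out lower numbers stand for stronger inhibition and higher numbers for weaker inhibition. Compound 1, with the structure `O=C(O)CN1Cc2ccc(NC(=O)c3ccc(C4CCNCC4)cc3)cc2C1=O`, gives 24000 nM in this assay, a higher number that lies beyond the scatter, so compound 2 stands as the lower of the two numbers shown. Compound 3, with the structure `O=C(O)CN1Cc2ccc(NC(=O)c3ccc(N4CCNCC4)cc3)cc2C1=O`, has not yet been measured; it differs from compound 2 in one place: carboxymethyl in place of 1-(carboxymethyl)ethyl on an amide-type nitrogen in a ring. No single-change step between measured compounds is shown, so the expectation rests on the change alone. The step from compound 2 to compound 3 is expected to be a 2.7-fold higher number from compound 2 to compound 3 (0.43 log units; beyond the scatter), toward a higher number. Compound 3 is estimated to give 10000 nM, in a range from 3000 nM to 35000 nM.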

Compound 3, half-maximal inhibitory concentration: 3300 nM
The estimate for compound 3 lay 3.0-fold (0.48 log units) above the measured number; low and high end bracket the measured number.
By their numbers in this assay, from the lowest: compounds 3 and 2 (each within the scatter of the next); then compound 1.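

Replacing 1-(carboxymethyl)ethyl with carboxymethyl on the amide-type nitrogen in a ring gives a 1.1-fold lower number from compound 2 to compound 3 (0.05 log units; within the scatter) in this assay and so leaves the number within the scatter. Piperazin-1-yl in place of piperidin-4-yl on an aromatic carbon gives a 7.3-fold lower number from compound 1 to compound 3 (0.86 log units; beyond the scatter) and so is the only one of these two changes that moves the number beyond the scatter. Nothing available explains either result.

From the compounds shown here alone, how a longer chain ending in the carboxylic acid, or an ester in place of that acid, would behave on this nitrogen remains open. So does the effect of a methyl group on the piperazin-1-yl ring.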